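Swapping methyl for fluoro on the outer aromatic ring

This account rests on a few compounds, and the source may have more. Where it says the series, first, only, none or still open, it means among the compounds named here.

Values in a functional assay on PC-3 cells (Homo sapiens) for cytotoxicity, read by MTT assay, with a stated time of 72 h; a higher number here means a weaker inhibitor, a lower number a stronger inhibitor:
Compound 1 `CNC(=O)c1cc(Oc2ccc(NC(=O)c3cc(-c4ccc(C)cc4)ncn3)cc2)ccn1`: > 100000 nM (a limit, not a number)
Compound 2 `CNC(=O)c1cc(Oc2ccc(NC(=O)c3nccc(-c4ccc(OC)cc4)n3)cc2)ccn1`: 14200 nM
Compound 3 `CNC(=O)c1cc(Oc2ccc(NC(=O)c3cc(-c4ccc(C)cc4)ncn3)cc2F)ccn1`: 40200 nM

Compound 1 stands at the limit of > 100000 nM in this assay, at which 1 of the 3 values shown sits. It therefore has no exact value to start from, and any step away from it can be sized only roughly.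

Compound 4 `CNC(=O)c1cc(Oc2ccc(NC(=O)c3cc(-c4ccc(F)cc4)ncn3)cc2)ccn1`, not yet measured, keeps the core of compound 1 and changes one group, from 4-methylphenyl to 4-fluorophenyl. This puts fluoro in place of methyl on an aromatic carbon, para to a large group (fluoro in place of methyl on an aromatic carbon).

Within the data shown here, no measured step makes this exact change. The closest is an at least 2.4-fold lower number from compound 1 to compound 3 (0.39 log units; beyond the scatter), which also brings in fluoro, but in place of hydrogen and elsewhere in the molecule. That makes it only a loose guide. It does suggest that a small change of this kind can move the result modestly, so a modest shift towards a lower number is the most reasonable expectation, though compound 4 could also stay at the limit.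

In this assay, the expected step is an at least 2.0-fold lower number from compound 1 to compound 4 (0.30 log units; that floor lies within the scatter). Compound 4 is estimated at 50000 nM, with an expected range from 15000 nM to 100000 nM.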

Compound 4, half-maximal inhibitory concentration: > 100000 nM
Compound 4 was reported as a limit (the forecaster's own chance of this, stated with the estimate: 40%); middle value at least 2.0-fold (0.30 log units) away from the limit.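

In this assay, compound 1 and compound 4 each carry only a limit rather than an exact number, so no step between the two can be read: the limit of > 100000 nM in this assay, at which 2 of the 4 values shown sit.

The compounds shown leave open whether 4-methylphenyl and 4-fluorophenyl differ at all on this shared core in this assay, and if they do, by how much.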